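The compounds below may be only part of what the source reports. "The series", "measured", "known", "first", "only" and "open" are said of these compounds alone.

Measured set in a functional assay on A549 cells (Homo sapiens) for cytotoxicity, read by MTT assay, with a stated time of 72 h; on this read-out lower numbers stand for stronger inhibition and higher numbers for weaker inhibition:

Compound 1 `COc1cccc(/C(=C\c2cn(C(C)=O)c3ccc(OCc4ccccc4)cc23)C(=O)O)c1` gives 45200 nM.
Compound 2 `CC(=O)n1cc(/C=C(/C(=O)O)c2ccccc2)c2cc(OCc3ccccc3)ccc21` gives 57500 nM.
Compound 3 `COc1ccc(OC)c(/C(=C\c2cn(C(C)=O)c3ccc(OCc4ccccc4)cc23)C(=O)O)c1` gives 54500 nM.

Compound 2 sits at the upper end of these three numbers, but both of its steps to the others are within the scatter: a 1.3-fold higher number from compound 1 to compound 2 (0.10 log units; within the scatter) and a 1.1-fold lower number from compound 2 to compound 3 (0.02 log units; within the scatter). The third step, a 1.2-fold higher number from compound 1 to compound 3 (0.08 log units; within the scatter), is likewise within the scatter, so nothing in the measured set separates the three analogues in this assay.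

Compound 4 `COc1cc(OC)cc(/C(=C\c2cn(C(C)=O)c3ccc(OCc4ccccc4)cc23)C(=O)O)c1` is the next analogue. The change from compound 2 is 3,5-dimethoxyphenyl in place of phenyl on a double-bonded chain carbon bound to a carbonyl carbon and a double-bonded chain carbon. Among the measured compounds shown here, two measured steps bear on it: the move from phenyl to a dimethoxyphenyl in the same place, a 1.1-fold lower number from compound 2 to compound 3 (0.02 log units; within the scatter), and the addition of a single methoxy on an aromatic carbon, a 1.2-fold higher number from compound 1 to compound 3 (0.08 log units; within the scatter). Neither step left the scatter. No step beyond the scatter in this assay is therefore expected for compound 4, in either direction.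

Compound 4 is estimated at 55000 nM in this assay, with a range of 30000 nM to 100000 nM. That estimate corresponds to an expected step of a 1.0-fold lower number from compound 2 to compound 4 (0.02 log units; within the scatter).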

Compound 4, half-maximal inhibitory concentration: 26000 nM
Estimate against measurement, compound 4: 2.1-fold (0.33 log units) above; the whole stated range lies above it.
By their numbers in this assay, from the lowest: compounds 4, 1, 3 and 2 (each within the scatter of the next, the first and the last beyond it).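

On the double-bonded chain carbon bound to a carbonyl carbon and a double-bonded chain carbon, the aryl substitution pattern now separates analogues in this assay: 3,5-dimethoxyphenyl gives a 2.2-fold lower number from compound 2 to compound 4 (0.34 log units; beyond the scatter) and a 2.1-fold lower number from compound 3 to compound 4 (0.32 log units; beyond the scatter), whereas 2,5-dimethoxyphenyl gave only a 1.1-fold lower number from compound 2 to compound 3 (0.02 log units; within the scatter). The added methoxy alone does not reach the same separation, with a 1.7-fold lower number from compound 1 to compound 4 (0.24 log units; within the scatter), so the effect of this change rests on the two modest steps. No measurement on hand bears on what underlies this difference.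

Open, from the compounds shown here alone, is whether the lower number holds when the two methoxy groups give way to ethoxy or hydroxyl groups on the same phenyl ring. Also open, going by these compounds, is whether it survives replacing the carboxylic acid with a methyl ester or a primary amide.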